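The source may hold more compounds than are shown below. What is called first, only, known or untested is meant among the compounds shown, and "the series" means these compounds.

Measured so far:
- compound 1, `OC[C@H]1O[C@@H](n2cnc3c(SCC4CCCCC4)ncnc32)[C@H](O)[C@@H]1O`: 1550 nM
- compound 2, `CSc1ncnc2c1c(Br)cn2[C@@H]1O[C@H](CO)[C@@H](O)[C@H]1O`: 115000 nM

Both compounds were tested in an assay on isolated protein for binding affinity to Equilibrative nucleoside transporter 1 (Homo sapiens); a lower number here means a stronger inhibitor, a higher number a weaker inhibitor. Compound 1 gives 1550 nM, the lowest of the two numbers, and compound 2 gives 115000 nM, a far higher number that lies well beyond the usual scatter of this assay. Compound 1 is therefore the stronger inhibitor of the pair by a clear margin, and it serves as the starting point for the next compound.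

Compound 3, `OC[C@H]1O[C@@H](n2cnc3c(CSc4ccc(Br)cc4)ncnc32)[C@H](O)[C@@H]1O`, is not yet measured. It differs from compound 1 in one place: ((4-bromophenyl)sulfanyl)methyl in place of (cyclohexylmethyl)sulfanyl on an aromatic carbon. Among the measured compounds shown here, because only one step from compound 1 to a measured neighbour exists, and that neighbour differs in more than one place, no single-change step is available to calibrate how such a swap moves the number. The expectation is nevertheless a modest weakening in this assay, a step from compound 1 to compound 3 of about a 2.3-fold higher number from compound 1 to compound 3 (0.35 log units; beyond the scatter), without a strong reason to predict a large shift in either direction. Compound 3 is thus estimated at 3500 nM, with a plausible range from 900 nM to 14000 nM.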

Compound 3, half-maximal inhibitory concentration: 178 nM
Beside the measured number, compound 3's estimate is 20-fold (1.29 log units) above it; the whole stated range lies above it.
By their numbers in this assay, from the lowest: compound 3; then compound 1; then compound 2.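

Among the compounds shown here, this is the first single change at this position on the core of compound 1, an aromatic carbon of the six-membered ring with 2 nitrogen, and it shows that the position responds strongly to what it carries: in this assay, ((4-bromophenyl)sulfanyl)methyl in place of (cyclohexylmethyl)sulfanyl gives an 8.7-fold lower number from compound 1 to compound 3 (0.94 log units; beyond the scatter). For the compounds shown here, a non-aromatic carbon ring can therefore be exchanged here for a brominated aromatic one with a stronger inhibitor as the outcome, although the single step changes the ring, adds bromine and moves the sulfur within the chain all at once. Nothing measured here gives a reason for the step or shows which of these differences accounts for it.

The compounds shown leave open how much of the step would remain with a plain phenyl ring without bromine, or with the sulfur attached directly to the core, as it is in compound 1. As far as these compounds go, it is also open whether the aromatic ring would accept an amine or a carboxylic acid in place of the bromine, and whether a longer chain between that ring and the core would move the number further.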